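This account rests on a few compounds, and the source may have more. Where it says the series, first, only, none or still open, it means among the compounds named here.

In a functional assay on CAL-51 cells (Homo sapiens) for inhibition, read by sulforhodamine B assay, with a stated time of 3 days (on this read-out lower numbers stand for stronger inhibition of growth and higher numbers for weaker inhibition of growth), compound 1 `Cc1ccc(COc2ccc(C(=O)/C=C/c3ccccc3)cc2)cc1` gives 43200 nM, compound 3 `O=C(/C=C/c1ccccc1)c1ccc(OCc2ccccc2)cc1` gives 28900 nM and compound 2 `O=C(/C=C/c1ccc(OCc2ccccc2)cc1)c1ccccc1` gives 24700 nM. Compound 2 thus stands within the scatter of both other compounds, and no order can be drawn among the three. The account now turns to compound 4 `O=C(/C=C/c1ccc(Cl)cc1)c1ccccc1`, which differs from compound 2 by one change: chloro in place of benzyloxy on an aromatic carbon. In words, this is chloro in place of benzyloxy on an aromatic carbon.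

Within the data shown here, only one measured step bears on this change, and only loosely: a 1.5-fold lower number from compound 1 to compound 3 (0.17 log units; within the scatter). That step is hydrogen in place of methyl on an aromatic carbon, and it stays within the scatter. No measured step removes a benzyloxy group, so the data give no direct evidence for its loss and no reason to expect a direction in this assay. The expected result, held with caution, is no shift beyond the scatter, an estimated 1.2-fold lower number from compound 2 to compound 4 (0.09 log units; within the scatter). The estimate for compound 4 is 20000 nM, with an expected range from 7000 nM to 60000 nM.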

Compound 4, concentration for 50% growth inhibition: 5850 nM
The estimate for compound 4 lay 3.4-fold (0.53 log units) above the measured number, and the stated range ends above it.
By their numbers in this assay, from the lowest: compound 4; then compounds 2, 3 and 1 (each within the scatter of the next).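

In this assay, among these compounds, this position gives the first step beyond the scatter, a 4.2-fold lower number from compound 2 to compound 4 (0.63 log units; beyond the scatter), a modest one, whereas the only earlier step stayed within it. The place on the aromatic carbon, para to a large group, therefore responds to what sits there, and the benzyloxy group with its eight heavy atoms and its ring is not required for growth inhibition, since a lone chloro gives the lower number. Nothing measured here accounts for this step.

The compounds shown leave open whether the shift comes from the chloro itself or simply from the loss of benzyloxy. Hydrogen, a methoxy group, an amine or a carboxylic acid at this same place would be the groups to separate those two readings.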